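This account rests on a few compounds, and the source may have more. Where it says the series, first, only, none or still open, it means among the compounds named here.

The measured compounds:
compound 1 `ClCc1ccccc1Cn1cnc2c(Cl)nc(Cl)nc21`, 350 nM
compound 2 `ClCc1ccccc1Cn1cnc2c(Cl)ncnc21`, 5010 nM
compound 3 `ClCc1cccc(Cn2cnc3ncnc(Cl)c32)c1`, 32400 nM

All three were tested in a functional assay on SW-620 cells (Homo sapiens) for cytotoxicity, read by sulforhodamine B assay, with a stated time of 48 h; a lower number here means a stronger inhibitor of growth, a higher number a weaker inhibitor of growth. Compound 1 gives 350 nM, compound 2 gives 5010 nM, and compound 3 gives 32400 nM, the highest number of the three. Compound 1 and compound 2 differ in one place: chloro in place of hydrogen on an aromatic carbon. That single change made a step of a 14-fold lower number from compound 2 to compound 1 (1.16 log units; beyond the scatter). Compound 3 has the same atoms as compound 2, joined differently; the difference between the two cores is not broken down here. Compound 4 `ClCc1cccc(Cn2cnc3nc(Cl)nc(Cl)c32)c1` has not yet been measured. It differs from compound 3 by chloro in place of hydrogen on an aromatic carbon, the same change as from compound 2 to compound 1, with the same surroundings word for word. Among the compounds with values here, only one earlier example of this change is known, so the expectation rests on it alone: the step is expected to be about a 12-fold lower number from compound 3 to compound 4 (1.06 log units; beyond the scatter), resting on the measured step of a 14-fold lower number from compound 2 to compound 1 (1.16 log units; beyond the scatter). Compound 4 is therefore estimated at 2800 nM, likely between 900 nM and 9000 nM.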

Compound 4, concentration for total growth inhibition: 1650 nM
The estimate for compound 4 lay 1.7-fold (0.23 log units) above the measured number; measured number inside the range.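

In this assay, putting a chloro in place of hydrogen on the aromatic carbon between two ring nitrogen atoms gave a 20-fold lower number from compound 3 to compound 4 (1.29 log units; beyond the scatter), and this step matches the earlier one on the other core: the same change on two cores in this assay, a 14-fold lower number (1.16 log units; beyond the scatter) from compound 2 to compound 1 and a 20-fold lower number (1.29 log units; beyond the scatter) from compound 3 to compound 4, 1.4-fold (0.14 log units) apart, within the scatter of two such steps So on these two cores, which hold the same atoms joined differently, the chloro lowered the number by about the same amount, and the earlier step was a fair guide to the new one. Within the data shown here, this rests on only two pairs of compounds in a single cell assay, so it does not show that the change would carry over to any further core, nor does it explain why the number falls.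

The compounds shown carry only a chloro or a hydrogen at this place, so it remains open how an amine, a methoxy group or a fluoro there would compare. The chloromethyl group is also present in all of them, which leaves open what a hydroxymethyl or a plain methyl in its place would do.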